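A few compounds are considered here, and "the series" means these few. Any claim that something is new, unique, unknown or untested is made for them only; others in the source may bear on it.

Working notes on the series, read in a functional assay on Huh-7 cells (Homo sapiens) for inhibition, read by sulforhodamine B assay, with a stated time of 72 h; on this read-out lower numbers stand for stronger inhibition and higher numbers for weaker inhibition.

Three compounds of the shared core carry a measured value. Compound 1 `CC(C)Cc1ccc(C(C)c2nnc3n2N=C(c2ccc(OC(F)(F)F)cc2)CS3)cc1` gives 3600 nM. Compound 2 `CC(C)Cc1ccc(C(C)c2nnc3n2N=C(c2ccc(Br)cc2)CS3)cc1` gives 4900 nM. Compound 3 `COc1ccc2cc(C(C)c3nnc4n3N=C(c3ccc(Br)cc3)CS4)ccc2c1` gives 9300 nM. On these three numbers compound 2 stands second highest; compound 1 sits nearest, compound 3 furthest, and both gaps lie within the scatter of this assay, so no order among them can be claimed.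

Among the compounds with values here, the one measured step that varies the same position is a 1.4-fold higher number from compound 1 to compound 2 (0.13 log units; within the scatter), a shift that stays within the scatter.

Compound 4 `CC(C)Cc1ccc(C(C)c2nnc3n2N=C(c2ccc(F)cc2)CS3)cc1` differs from compound 2 in one place:
fluoro in place of bromo on an aromatic carbon

This change touches the same aromatic carbon as the step from compound 1 to compound 2, which moved the number by only a small amount. Within the data shown here, no measured step in this set moves the read-out beyond the scatter, so a step in this assay of about the same small size, in either direction, is expected here. For compound 4 the estimated value in this assay is 5000 nM, with an expected range from 2500 nM to 10000 nM. The expected step is a 1.0-fold higher number from compound 2 to compound 4 (0.01 log units; within the scatter).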

Compound 4, half-maximal inhibitory concentration: 7800 nM
Estimate against measurement, compound 4: 1.6-fold (0.19 log units) below; the measured number falls inside the stated range.
By their numbers in this assay, from the lowest: compounds 1, 2, 4 and 3 (each within the scatter of the next, the first and the last beyond it).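

The change from bromo to fluoro on this aromatic carbon gives a 1.6-fold higher number from compound 2 to compound 4 (0.20 log units; within the scatter), so in this assay this swap of one halogen for another cannot be separated from repeat variation. The same position does, however, now show its first step beyond the scatter, though only a modest one: fluoro in place of trifluoromethoxy gives a 2.2-fold higher number from compound 1 to compound 4 (0.34 log units; beyond the scatter), while compound 2 cannot be separated from either compound 1 or compound 4. Nothing available accounts for this difference at the position.

From the compounds shown here alone, whether an amine, a carboxylic acid or a nitrile on this carbon would take the number outside the narrow span seen so far remains open. Also open, going by these compounds, is whether fluoro and trifluoromethoxy would separate in the same way with the other side group of compound 3 on the shared core.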